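Swapping the amide-bound aryl: from difluorophenyl to bromophenyl

The compounds below may be only part of what the source reports. "The series", "measured", "known", "first", "only" and "open" are said of these compounds alone.

Three compounds share one core and differ in the group on the amide nitrogen. Compound 1 `O=C(CN1CCN(c2nnc(Cc3ccncc3)c3ccccc23)CC1)Nc1ccc(F)c(Cl)c1` gives 880 nM in a functional assay on HT-29 cells (Homo sapiens) for cytotoxicity, read by MTT assay, with a stated time of 72 h; on this read-out higher numbers stand for weaker inhibition and lower numbers for stronger inhibition. Compound 2 `O=C(CN1CCN(c2nnc(Cc3ccccc3)c3ccccc23)CC1)Nc1ccc(F)c(F)c1` gives 9510 nM, the second highest of the three numbers; compound 3 `O=C(CN1CCN(c2nnc(Cc3ccccc3)c3ccccc23)CC1)Nc1ccc(Br)cc1` gives 60200 nM, the highest. Among the measured compounds shown here, only one single-point step is known here: a 6.3-fold higher number from compound 2 to compound 3 (0.80 log units; beyond the scatter), a modest weakening of inhibition.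

Compound 4 `O=C(CN1CCN(c2nnc(Cc3ccccc3)c3ccccc23)CC1)Nc1cccc(Br)c1` follows from compound 2 by this change: 3-bromophenyl in place of 3,4-difluorophenyl on an amide-type nitrogen. Compound 4 thus carries a bromine on the phenyl ring, as compound 3 does, but attached at a different position of the ring, so the step from compound 2 to compound 3 bears on it only loosely. For the measured compounds named here, that step went toward weaker inhibition, and the same direction is expected for compound 4, with wide uncertainty since no single-point step with 3-bromophenyl has been measured. Compound 4 is therefore estimated at 25000 nM, within 6000 nM to 100000 nM, meaning an expected step of a 2.6-fold higher number from compound 2 to compound 4 (0.42 log units; beyond the scatter).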

Compound 4, half-maximal inhibitory concentration: 13400 nM
For compound 4 the middle estimate is 1.9-fold (0.27 log units) above the measured one; measured number inside the range.
By their numbers in this assay, from the lowest: compound 1; then compounds 2 and 4 (each within the scatter of the next); then compound 3.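

In this assay, 3-bromophenyl in place of 4-bromophenyl gives a 4.5-fold lower number from compound 3 to compound 4 (0.65 log units; beyond the scatter), so on this amide nitrogen it matters where the bromine sits on the phenyl ring, not only that it is present. Against 3,4-difluorophenyl, 3-bromophenyl gives a 1.4-fold higher number from compound 2 to compound 4 (0.15 log units; within the scatter), so these two groups cannot be told apart here, and the weaker inhibition seen with compound 3 does not extend to both bromophenyl groups. Nothing shown here explains either result.

On these data alone, it remains open whether an amine or a carboxylic acid in place of the bromine on this phenyl ring would give a similar number. Compound 1 differs from the other compounds in more than one place, so its steps to them cannot be read.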